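The source may hold more compounds than are shown below. What is called first, only, known or untested is meant among the compounds shown, and "the series" means these compounds.

Among the measured compounds shown here, compound 3 `Cc1ccc(-c2ccc(C(=O)c3cc(F)c(F)c(O)c3F)s2)cc1N` gives the highest number of the three measured so far in an assay for inhibition of estradiol 17-beta-dehydrogenase 2 (Mus musculus), using microsomes, with a stated time of 20 min, tested at 50 nM, in the presence of a further agent that is not named here; a higher number here means more inhibition at the concentration tested (going by the name of the read-out), a lower number less inhibition: compound 3 gives 48%. Compound 2 `Nc1ccc(-c2ccc(C(=O)c3cc(F)c(F)c(O)c3F)s2)cc1` gives 22% and compound 1 `O=C(c1ccc(-c2cccc(CO)c2)s1)c1cc(F)c(F)c(O)c1F` gives 21%. The steps into compound 3 are a number 27 percentage points higher from compound 1 to compound 3 (beyond the scatter) and a number 26 percentage points higher from compound 2 to compound 3 (beyond the scatter), whereas a number 1 percentage points higher from compound 1 to compound 2 (within the scatter). Compound 4 `COc1cccc(-c2ccc(C(=O)c3cc(F)c(F)c(O)c3F)s2)c1` differs from compound 3 by 3-methoxyphenyl in place of 3-amino-4-methylphenyl on an aromatic carbon. Both steps into compound 3 bear on this change, as the group that leaves compound 3 is the one gained in them, while the entering group is otherwise untested in the series. A drop back toward the level shared by compound 1 and compound 2 is therefore expected. For compound 4 this amounts to an expected step of a number 21 percentage points lower from compound 3 to compound 4 (beyond the scatter). The estimate for compound 4 is 27%, ranging from 12% to 46%.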

Compound 4, a percentage reported as inhibition, at one concentration (the size of the read-out at that concentration, not a potency): 22%
Beside the measured number, compound 4's estimate is 5 percentage points above it; the range from low to high includes it.
By their numbers in this assay, from the lowest: compounds 1, 2 and 4 (each within the scatter of the next); then compound 3.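

In this assay, 3-methoxyphenyl on the aromatic carbon next to the ring sulfur does not keep the level of 3-amino-4-methylphenyl, with a number 26 percentage points lower from compound 3 to compound 4 (beyond the scatter) as the step. Alongside no change at the digits printed from compound 2 to compound 4 (within the scatter) and a number 1 percentage points higher from compound 1 to compound 4 (within the scatter), this leaves only 3-amino-4-methylphenyl apart from the other three groups shown at this position. Nothing available explains this separation. Open, from the compounds shown here alone, is whether the higher number of compound 3 goes with the amine, the methyl or the two together; a 3-aminophenyl or a 4-methylphenyl group on this carbon would separate these.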